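Methoxy for chloro, second occurrence in the amide series

A few compounds are considered here, and "the series" means these few. Any claim that something is new, unique, unknown or untested is made for them only; others in the source may bear on it.

Of the compounds shown here, three on a shared core have been measured. Compound 1 `O=C(CO[N+](=O)[O-])Nc1ccc(C(=O)/C=C/c2ccc(Cl)cc2)cc1` gives 42% in a functional assay on the whole organism (strain albino) for inhibition, with Rattus norvegicus as the target, read by paw edema, with stated times of 30 min and 1 h, at a dose of 100 mg/kg by the oral route; a lower number here means less inhibition, a higher number more inhibition at the dose given (going by the name of the read-out). Compound 2 `COc1ccc(/C=C/C(=O)c2ccc(NC(=O)CO[N+](=O)[O-])cc2)cc1` gives 33% in this assay; the change methoxy in place of chloro on an aromatic carbon made the step of a number 9 percentage points lower from compound 1 to compound 2 (within the scatter). Compound 3 `CC(Br)C(=O)Nc1ccc(C(=O)/C=C/c2ccc(Cl)cc2)cc1` gives 39% in this assay, and the step of a number 3 percentage points lower from compound 1 to compound 3 (within the scatter) goes with the change of 1-bromoethyl in place of (nitrooxy)methyl on a carbonyl carbon. Compound 3 stands second highest of the three numbers, but compound 1 and compound 2 are both within the scatter of it, so no order among the three is claimed.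

Compound 4 `COc1ccc(/C=C/C(=O)c2ccc(NC(=O)C(C)Br)cc2)cc1` is not yet measured. It differs from compound 3 by methoxy in place of chloro on an aromatic carbon. This is the same change as from compound 1 to compound 2, with the place described in the same words, and it occurs twice in the set. The two cores on which it is made differ by 1-bromoethyl in place of (nitrooxy)methyl on a carbonyl carbon.

Among the measured compounds shown here, the expected step is a number 9 percentage points lower from compound 3 to compound 4 (within the scatter), resting on a number 9 percentage points lower from compound 1 to compound 2 (within the scatter) as the only earlier instance of this change. Compound 4 is therefore estimated at 30%, between 18% and 42%.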

Compound 4, a percentage reported as inhibition, in the whole organism at one dose (the size of the read-out at that dose, not a potency): 39%
Beside the measured number, compound 4's estimate is 9 percentage points below it; the measured number falls inside the stated range.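

In this assay, methoxy in place of chloro gives no change at the digits printed from compound 3 to compound 4 (within the scatter), and the two instances of this change cannot be told apart: the same change on two cores in this assay, a number 9 percentage points lower (within the scatter) from compound 1 to compound 2 and no change at the digits printed (within the scatter) from compound 3 to compound 4, 9 percentage points apart, within the scatter of two such steps. The exchange of the group on the carbonyl carbon, read on the methoxy-bearing core, gives a number 6 percentage points higher from compound 2 to compound 4 (within the scatter), and it too agrees with its earlier instance: the same change on two cores in this assay, a number 3 percentage points lower (within the scatter) from compound 1 to compound 3 and a number 6 percentage points higher (within the scatter) from compound 2 to compound 4, 9 percentage points apart, within the scatter of two such steps. Nothing here argues against carrying either change from one core to the other, but every step lies within the scatter, so the data do not show that either change has any effect on this read-out, and agreement between two small steps on two cores is no evidence of a transferable effect.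

The compounds shown leave open whether a different group on that aromatic carbon, such as an amine or a carboxylic acid, would give a step beyond the scatter. They also leave open whether a longer chain on the carbonyl carbon would do so, and whether either change would behave alike on further cores.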